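Swapping Sulfanyl for Bromo on a Shared Core

A few compounds are considered here, and "the series" means these few. Any claim that something is new, unique, unknown or untested is made for them only; others in the source may bear on it.

Compound 1 `Nc1nc2c(Cl)c(Cl)ccc2n1COC(CO)CO` — > 100000 nM
Compound 2 `OCC(CO)OCn1cnc2c(Cl)c(Cl)ccc21` — > 100000 nM
Compound 3 `OCC(CO)OCn1c(S)nc2c(Cl)c(Cl)ccc21` — > 100000 nM

All three compounds were tested in a functional assay on KB cells (Homo sapiens) for inhibition; a higher number here means a weaker inhibitor, a lower number a stronger inhibitor. The value of compound 1 in this assay is a limit of the assay, not a number. The same holds for compound 2, whose value is only a limit. Compound 3 likewise gives only a limit, so no number is known for it; it stands at the same limit as the other two. Because all three values sit at the limit of > 100000 nM in this assay, at which 3 of the 3 values shown sit, the steps a step that the two limits leave unreadable from compound 1 to compound 2, a step that the two limits leave unreadable from compound 1 to compound 3 and a step that the two limits leave unreadable from compound 2 to compound 3 cannot be sized; they say only that neither amino, hydrogen nor sulfanyl at that carbon brought the compounds below the limit.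

Compound 4 `OCC(CO)OCn1c(Br)nc2c(Cl)c(Cl)ccc21` differs from compound 3 by bromo in place of sulfanyl on an aromatic carbon. Among the compounds with values here, no measured step involves bromo at this carbon, and none of the measured steps is readable, so nothing points to a change in either direction beyond the scatter. Compound 4 is therefore expected to stay weak, estimated at 100000 nM with a range from 30000 nM to 300000 nM. That estimate means a step of a number no higher from compound 3 to compound 4 (the limit leaves the size open) is expected, most likely reported again only as a limit.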

Compound 4, half-maximal inhibitory concentration: > 100000 nM
Compound 4: no number, only a limit; the forecaster's own chance of this, stated with the estimate: 70%; the middle value lies on the limit itself.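

In this assay compound 4 gives > 100000 nM, which is a limit and not a number. Its steps to compound 1, compound 2 and compound 3 cannot be read, because all four compounds sit at one limit: the limit of > 100000 nM in this assay, at which 4 of the 4 values shown sit.

The compounds shown leave open how amino, hydrogen, sulfanyl and bromo at this carbon truly rank against one another.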